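The compounds below may be only part of what the source reports. "The series", "measured", "known", "first", "only" and "open" are said of these compounds alone.

Three compounds have been measured in an ADME assay on HEK-293T cells (Homo sapiens) for cytotoxicity, read by MTT assay, with a stated time of 24 h; a higher number here means that more compound is tolerated, a lower number that less compound is tolerated:

Compound 1 `Cc1ccc(C(=O)n2c(-c3cn(-c4ccccc4)nc3-c3ccc(F)cc3)nc3ccccc32)cc1` gives 178000 nM.
Compound 2 `Cc1ccc(C(=O)n2c(-c3cn(-c4ccccc4)nc3-c3ccc(F)cc3)nc3ccccc32)cn1` gives 137000 nM.
Compound 3 `Cc1ccc(C(=O)n2c(-c3cn(-c4ccccc4)nc3-c3ccc(C)cc3)nc3ccccc32)cc1` gives 176000 nM.

Compound 4 `Cc1ccc(-c2nn(-c3ccccc3)cc2-c2nc3ccccc3n2C(=O)c2ccc(C)nc2)cc1` has not yet been measured in this assay. It differs from compound 3 in one place: 6-methylpyridin-3-yl in place of 4-methylphenyl on a carbonyl carbon. The same change, at a place described in the same words, was already made between two measured compounds and gave a 1.3-fold lower number from compound 1 to compound 2 (0.11 log units; within the scatter). The cores of compound 1 and compound 3 differ by methyl in place of fluoro on an aromatic carbon, and that change gave a 1.0-fold lower number from compound 1 to compound 3 (0.00 log units; within the scatter). From compound 3 to compound 4 a step of about the same size is expected, a 1.3-fold lower number from compound 3 to compound 4 (0.11 log units; within the scatter), resting on the earlier step of a 1.3-fold lower number from compound 1 to compound 2 (0.11 log units; within the scatter), which stayed within the scatter. On that basis compound 4 is estimated at 137000 nM, with a likely range from 70000 nM to 260000 nM.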

Compound 4, half-maximal cytotoxic concentration: 145000 nM
For compound 4 the middle estimate is 1.1-fold (0.02 log units) below the measured one; low and high end bracket the measured number.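

In this assay, 6-methylpyridin-3-yl in place of 4-methylphenyl on a carbonyl carbon gives a 1.2-fold lower number from compound 3 to compound 4 (0.08 log units; within the scatter), and this matches its effect on the other core: the same change on two cores in this assay, a 1.3-fold lower number (0.11 log units; within the scatter) from compound 1 to compound 2 and a 1.2-fold lower number (0.08 log units; within the scatter) from compound 3 to compound 4, 1.1-fold (0.03 log units) apart, within the scatter of two such steps. Methyl in place of fluoro on an aromatic carbon gives a 1.1-fold higher number from compound 2 to compound 4 (0.02 log units; within the scatter), and it carries over in the same way: the same change on two cores in this assay, a 1.0-fold lower number (0.00 log units; within the scatter) from compound 1 to compound 3 and a 1.1-fold higher number (0.02 log units; within the scatter) from compound 2 to compound 4, 1.1-fold (0.03 log units) apart, within the scatter of two such steps. Going by these compounds alone, all of these steps stay within the scatter, so the agreement shows only that neither change moves the number measurably on these two cores, not that either would behave the same on any other core.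

The compounds shown leave open whether a different group would give a step beyond the scatter. Examples are an amine or a carboxylic acid in place of the 4-methylphenyl, or a longer chain in place of the fluoro.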